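Removing the methoxycarbonyl group from compound 2

A few compounds are considered here, and "the series" means these few. Any claim that something is new, unique, unknown or untested is made for them only; others in the source may bear on it.

Values in a functional assay on A549 cells (Homo sapiens) for inhibition, read by CCK-8 assay, with a stated time of 72 h, tested at 1 uM (a higher number here means more inhibition of growth at the concentration tested, a lower number less inhibition of growth), are as follows
compound 1 `CN(C)C(=O)c1cc2cnc(Nc3ccc(NC(=O)C4(C(=O)Nc5cccc(F)c5)CC4)cc3)nc2n1C1CCCC1` gives 33.2%
compound 2 `COC(=O)c1cccc(NC(=O)C2(C(=O)Nc3ccc(Nc4ncc5cc(C(=O)N(C)C)n(C6CCCC6)c5n4)cc3)CC2)c1` gives 10.5%

Compound 2 is the lower of the two at 10.5% and lies beyond the scatter from compound 1. Compound 3 `CN(C)C(=O)c1cc2cnc(Nc3ccc(NC(=O)C4(C(=O)Nc5ccccc5)CC4)cc3)nc2n1C1CCCC1` has hydrogen in place of methoxycarbonyl on an aromatic carbon as its change from compound 2. Among the measured compounds shown here, the one measured step bearing on this is a number 22.7 percentage points lower from compound 1 to compound 2 (beyond the scatter) with methoxycarbonyl in place of fluoro on an aromatic carbon. For the measured compounds named here, a rise of similar size is therefore expected in this assay although no measurement yet compares hydrogen with fluoro. The expected step is a number 19.5 percentage points higher from compound 2 to compound 3 (beyond the scatter) on this reading. Compound 3 is estimated at 30% with an expected range from 15% to 45% in all.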

Compound 3, percent growth inhibition at one concentration: 75%
For compound 3 the middle estimate is 45 percentage points below the measured one; the measured number lies above the stated range.
By their numbers in this assay, from the lowest: compound 2; then compound 1; then compound 3.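

Replacing methoxycarbonyl by hydrogen on this six-membered aromatic ring gives, in this assay, a number 64.5 percentage points higher from compound 2 to compound 3 (beyond the scatter), while replacing fluoro by hydrogen gives a number 41.8 percentage points higher from compound 1 to compound 3 (beyond the scatter). The earlier step showed only that methoxycarbonyl fell short of fluoro; these steps show that both groups fall short of hydrogen at this place, so fluoro also carries a cost. No available evidence explains this.

From the compounds shown here alone, whether an amine, a carboxylic acid or a methoxy group at this place would also fall short of hydrogen remains open. So does whether any group here can match compound 3.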